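The compounds below may be only part of what the source reports. "The series", "measured", "known", "first", "only" and "open" are said of these compounds alone.

Measured in a functional assay on NCI-H1299 cells (Homo sapiens), read by flow cytometry; a lower number here means that less compound is needed, a higher number that more compound is needed for the effect:
Compound 1 `CCOc1ccc2c(c1)NC(=O)Nc1cnc(C#N)c(n1)OCC/C=C\CO2`: > 10000 nM (a limit)
Compound 2 `COc1ccc2c(c1)NC(=O)Nc1cnc(C#N)c(n1)OCCCCCO2`: > 10000 nM (a limit)

Compound 1 has no numerical value, only the limit > 10000 nM. The same holds across the pair, with the record standing at the limit of > 10000 nM in this assay, at which 2 of the 2 values shown sit. Neither compound therefore gives a number from which to measure a step.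

Compound 3 `N#Cc1ncc2nc1OCC/C=C\COc1ccc(CCCOC3CCCCO3)cc1NC(=O)N2` is the next to be measured. It carries 3-((oxan-2-yl)oxy)propyl in place of ethoxy on an aromatic carbon of the core of compound 1: 3-((oxan-2-yl)oxy)propyl in place of ethoxy on an aromatic carbon.

Among the measured compounds shown here, no measured step bears on this change. Since compound 1 reads > 10000 nM, no step beyond the scatter is expected in this assay, and a further limit is the likeliest result. The expected step is a number no higher from compound 1 to compound 3 (the limit leaves the size open). For compound 3 the estimate is 10000 nM, with an expected range of 3000 nM to 30000 nM.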

Compound 3, half-maximal effective concentration: > 10000 nM
Compound 3 ended at the assay's limit (the forecaster's own chance of this, stated with the estimate: 75%); the middle value sits exactly at the limit.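

Compound 3, like compound 1, gives only a limit, so no step can be read for 3-((oxan-2-yl)oxy)propyl in place of ethoxy: the limit of > 10000 nM in this assay, at which 3 of the 3 values shown sit.

The compounds shown leave open which change to the shared core, if any, gives a numerical value in this assay.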